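The compounds below may be only part of what the source reports. "The series", "measured", "known", "first", "only" and "open" are said of these compounds alone.

Measured compounds:
Compound 1, `CC(C)(C)NC(=O)c1c(N)sc(-c2ccc(Cl)cc2)c1-c1ccc(Cl)cc1`: in a functional assay on A549 cells (Homo sapiens) for inhibition, read by sulforhodamine B assay, with a stated time of 72 h (on this read-out lower numbers stand for stronger inhibition and higher numbers for weaker inhibition), compound 1 gives 8850 nM.
Compound 2, `COC(=O)c1c(N)sc(-c2ccc(Cl)cc2)c1-c1ccc(Cl)cc1`: compound 2 gives 5040 nM.
Compound 3, `Nc1sc(-c2ccc(Cl)cc2)c(-c2ccc(Cl)cc2)c1C(=O)NC1CCC1`: compound 3 gives 12500 nM.

Compound 3 has the highest of the three numbers; its nearest neighbour is compound 1, with a 1.4-fold higher number from compound 1 to compound 3 (0.15 log units; within the scatter), and its furthest is compound 2, with a 2.5-fold higher number from compound 2 to compound 3 (0.39 log units; beyond the scatter).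

Compound 4, `Nc1sc(-c2ccc(Cl)cc2)c(-c2ccc(Cl)cc2)c1C(=O)Nc1ccccc1`, differs from compound 3 by phenyl in place of cyclobutyl on an amide-type nitrogen. Among the compounds with values here, the only measured step at the same place is a 1.4-fold higher number from compound 1 to compound 3 (0.15 log units; within the scatter), a swap of two non-aromatic groups on the amide-type nitrogen; a 2.5-fold higher number from compound 2 to compound 3 (0.39 log units; beyond the scatter) changes the carbonyl substituent itself. Within the data shown here, no step introduces an aromatic group at this position, so the basis is thin. The expected step is a 1.3-fold lower number from compound 3 to compound 4 (0.10 log units; within the scatter), not beyond the scatter. Compound 4 is estimated at 10000 nM, range 3500 nM to 30000 nM.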

Compound 4, half-maximal inhibitory concentration: 25000 nM
The estimate for compound 4 lay 2.5-fold (0.40 log units) below the measured number; low and high end bracket the measured number.
By their numbers in this assay, from the lowest: compounds 2, 1, 3 and 4 (each within the scatter of the next, the first and the last beyond it).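

In this assay, within the data shown here, the first aromatic group on the amide-type nitrogen, phenyl, stays within the scatter of cyclobutyl, with a 2.0-fold higher number from compound 3 to compound 4 (0.30 log units; within the scatter) as the step, but not of tert-butyl, with a 2.8-fold higher number from compound 1 to compound 4 (0.45 log units; beyond the scatter) as the step. Anilino in place of methoxy on the carbonyl carbon gives a 5.0-fold higher number from compound 2 to compound 4 (0.70 log units; beyond the scatter) as the widest step so far, so phenyl brings no gain here. No available data explain these steps. Still open, going by these compounds, is whether a benzyl group or a pyridine ring on this nitrogen, or a carboxylic acid in place of the amide, would lower the number.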